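The source may hold more compounds than are shown below. What is called first, only, known or untested is meant among the compounds shown, and "the series" means these compounds.

Compound 1 `COc1cc(/C=C/C(=O)/C=C/c2cccc3ccccc23)ccc1OCc1cn(CCCCOc2cc(=O)oc3ccccc23)nn1`: 54%
Compound 2 `COc1cc(/C=C/C(=O)/C=C/c2ccco2)ccc1OCc1cn(CCCCOc2cc(=O)oc3ccccc23)nn1`: 49%

In a functional assay on THP-1 cells (Homo sapiens) for inhibition, read by sulforhodamine B assay, with a stated time of 48 h, tested at 50 uM (a higher number here means more inhibition of growth at the concentration tested, a lower number less inhibition of growth), compound 2 gives 49%, which cannot be told apart from compound 1 at 54%. Compound 3 `COc1cc(/C=C/C(=O)/C=C/c2cccs2)ccc1OCc1cn(CCCCOc2cc(=O)oc3ccccc23)nn1` has thiophen-2-yl in place of furan-2-yl on a double-bonded chain carbon bound to a double-bonded chain carbon. Among the measured compounds shown here, the one measured step at this place, naphthalen-1-yl to furan-2-yl, is a number 5 percentage points lower from compound 1 to compound 2 (within the scatter). A step beyond the scatter is therefore not expected, and the estimated change is a number 2 percentage points higher from compound 2 to compound 3 (within the scatter). In this assay, the expected value for compound 3 is 51%, with an estimated range of 41% to 61%.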

Compound 3, percent growth inhibition at one concentration: 44%
Compound 3: the middle estimate sits 7 percentage points above what was measured; low and high end bracket the measured number.
By their numbers in this assay, from the lowest: compounds 3, 2 and 1 (each within the scatter of the next).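

In this assay, the exchange of furan-2-yl for thiophen-2-yl, which puts sulfur in place of oxygen in a five-membered aromatic ring, is a number 5 percentage points lower from compound 2 to compound 3 (within the scatter), and thiophen-2-yl in place of naphthalen-1-yl is a number 10 percentage points lower from compound 1 to compound 3 (within the scatter). All three groups at this place therefore stand within the scatter of one another, whether the group is one five-membered ring or naphthalen-1-yl. No evidence is available that would explain these numbers. As far as these compounds go, whether 4-(dimethylamino)phenyl or 4-carboxyphenyl at this place would give a step beyond the scatter remains open.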